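Replacing the Benzyloxycarbonyl Group on Compound 3

This account rests on a few compounds, and the source may have more. Where it says the series, first, only, none or still open, it means among the compounds named here.

Compound 1 `COc1cc(OC)c2cc(-c3ccccc3)c(O)nc2c1` gives 10000 nM
Compound 2 `COc1cc(OC)c2cc(-c3ccc(OCc4ccccc4)cc3)c(O)nc2c1` gives 10000 nM
Compound 3 `COc1ccc(-c2cc3c(OC)cc(OC)cc3n(CC(=O)OCc3ccccc3)c2=O)cc1` gives 10000 nM

In a functional assay on MCF7 cells (Homo sapiens) for cytotoxicity, read by colorimetric assay and MTT assay (a lower number here means a stronger inhibitor, a higher number a weaker inhibitor), compound 3 stands level with compound 1 and compound 2, with no difference at the digits reported. The next compound, compound 4 `COc1ccc(-c2cc3c(OC)cc(OC)cc3n(CCC(=O)OCc3ccccc3)c2=O)cc1`, differs from compound 3 at a single place: (benzyloxycarbonyl)methyl in place of benzyloxycarbonyl on a saturated chain carbon bound to an aromatic nitrogen. Here (benzyloxycarbonyl)methyl stands in place of benzyloxycarbonyl on a saturated chain carbon bound to an aromatic nitrogen. Within the data shown here, no measured step covers this change directly. Among the measured compounds shown here, the only one available is no change at the digits printed from compound 1 to compound 2 (within the scatter), with benzyloxy in place of hydrogen on an aromatic carbon. It lies elsewhere in the structure, so it bears only loosely on this change. With nothing here separating any two compounds, no step beyond the scatter is expected in this assay, in either direction. The expected step is no change at the digits printed from compound 3 to compound 4 (within the scatter). The estimate for compound 4 is 10000 nM, with an expected range from 4000 nM to 20000 nM.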

Compound 4, half-maximal inhibitory concentration: 10000 nM
Beside the measured number, compound 4's estimate shows no gap at the digits printed, and the stated range covers the measured number.
By their numbers in this assay, from the lowest: compounds 1, 2, 3 and 4 (each within the scatter of the next).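

In this assay, the swap of benzyloxycarbonyl for (benzyloxycarbonyl)methyl on a saturated chain carbon bound to an aromatic nitrogen gives no change at the digits printed from compound 3 to compound 4 (within the scatter). Among these compounds, this position therefore has a measured step of its own, whereas the only earlier step, no change at the digits printed from compound 1 to compound 2 (within the scatter), lay elsewhere in the structure. Nothing available offers an explanation for this result.

Going by these compounds, whether a carboxylic acid in place of the benzyloxycarbonyl group, or an amine on the same chain, would shift the reading remains open. Since all four compounds read the same, none of them shows which structural change, at this position or any other on the shared core, could move the number beyond the scatter.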